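Working notes: replacing cyano on compound 3

A few compounds are considered here, and "the series" means these few. Any claim that something is new, unique, unknown or untested is made for them only; others in the source may bear on it.

Measured in an ADME assay on a cell-free system (plasma, Homo sapiens); a higher number here means a larger unbound share of the compound, a lower number a smaller unbound share:
- compound 1 `CCNC(=O)Nc1nc2cc(-c3cccnc3)c(=O)n(C(C)C)c2s1`: 0.21
- compound 2 `CCNC(=O)Nc1nc2cc(-c3ccc(OC)nc3)c(=O)n(C(C)C)c2s1`: 0.05
- compound 3 `CCNC(=O)Nc1nc2cc(-c3ccc(C#N)nc3)c(=O)n(C(C)C)c2s1`: 0.04

Compound 3 stands at the low end of this set, level with compound 2 and clearly under compound 1. Compound 4 `CCNC(=O)Nc1nc2cc(-c3ccc(-c4nnn(C)n4)nc3)c(=O)n(C(C)C)c2s1` carries 2-methyl-2H-tetrazol-5-yl in place of cyano on an aromatic carbon. Two measured steps replace hydrogen at this place, a 4.2-fold lower number from compound 1 to compound 2 (0.62 log units; beyond the scatter) and a 5.3-fold lower number from compound 1 to compound 3 (0.72 log units; beyond the scatter). Going by the values given here, the one exchange of one group for another there is closer to the present change, and it stayed small: a 1.3-fold lower number from compound 2 to compound 3 (0.10 log units; within the scatter). On that basis, no large further move is expected in this assay. The expected step is a 1.3-fold lower number from compound 3 to compound 4 (0.12 log units; within the scatter). Compound 4 is estimated at 0.03, with an expected range of 0.015 to 0.07.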

Compound 4, unbound fraction: 0.08
The estimate for compound 4 lay 2.7-fold (0.43 log units) below the measured number; the whole stated range lies below it.
By their numbers in this assay, from the lowest: compounds 3, 2 and 4 (each within the scatter of the next); then compound 1.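

In this assay, exchanging cyano for the much bulkier 2-methyl-2H-tetrazol-5-yl leaves the unbound share level at this place: a 2.0-fold higher number from compound 3 to compound 4 (0.30 log units; within the scatter), and against methoxy, a 1.6-fold higher number from compound 2 to compound 4 (0.20 log units; within the scatter). Going by these compounds alone, only the step from hydrogen stays beyond the scatter, a 2.6-fold lower number from compound 1 to compound 4 (0.42 log units; beyond the scatter), so methoxy, cyano and 2-methyl-2H-tetrazol-5-yl all sit under compound 1 without separating from one another. No supporting data bear on why these three groups fall together.

Still open, going by these compounds, is whether an amine or a carboxylic acid at this place would separate from these three groups in this assay.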